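The source may report more compounds than this note shows. Statements on the series, on what has been measured and on what is new or still open speak of the compounds shown alone.

Compound 1 `COc1cc(-c2nnc(SCC(=O)c3ccc(Cl)cc3)n2N)cc(OC)c1OC`: > 100000 nM
Compound 2 `COc1cc(-c2nnc(SCC(=O)c3ccc(F)cc3)n2N)cc(OC)c1OC`: > 100000 nM
Compound 3 `COc1cc(-c2nnc(SCC(=O)c3ccccc3F)n2N)cc(OC)c1OC`: 43100 nM

In a functional assay on PC-3 cells (Homo sapiens) for antiproliferative activity, read by MTT assay, with a stated time of 48 h (a lower number here means a stronger inhibitor, a higher number a weaker inhibitor), compound 1 reaches only > 100000 nM, which is a limit of the assay rather than a number. Compound 2 likewise stops at the limit > 100000 nM. Going by the values given here, compound 3 gives 43100 nM, the only real number among the three, and it stands at the active end of the series: an at least 2.3-fold lower number from compound 1 to compound 3 (0.36 log units; beyond the scatter) and an at least 2.3-fold lower number from compound 2 to compound 3 (0.36 log units; beyond the scatter), both beyond the scatter. Compound 4 `COc1cc(-c2nnc(SCC(=O)Nc3ccccc3C)n2N)cc(OC)c1OC` is built from compound 3 by the change ((2-methylphenyl)amino in place of 2-fluorophenyl on a carbonyl carbon). Among the compounds with values here, no measured step touches the carbonyl side in this way; the steps seen move only a halogen on the aryl ring, so they give little guidance here. The number for compound 4 is therefore expected to stay close to that of compound 3, a 1.1-fold lower number from compound 3 to compound 4 (0.03 log units; within the scatter), with a wide spread. The estimate for compound 4 is 40000 nM, expected between 8000 nM and 200000 nM.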

Compound 4, half-maximal inhibitory concentration: > 100000 nM
Compound 4: only a limit was reported (the forecaster's own chance of this, stated with the estimate: 35%); middle value at least 2.5-fold (0.39 log units) away from the limit.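

Putting (2-methylphenyl)amino in place of 2-fluorophenyl on the carbonyl carbon gives an at least 2.3-fold higher number from compound 3 to compound 4 (0.36 log units; beyond the scatter), so the only measurable activity in this set does not survive this change. In this assay compound 4 gives > 100000 nM, which is a limit of the assay and not a number. The steps from compound 1 and compound 2 to compound 4 cannot be read: the limit of > 100000 nM in this assay, at which 3 of the 4 values shown sit.

As far as these compounds go, the change swaps the aryl group and adds the amide hydrogen together, so which part matters stays open. A (2-fluorophenyl)amino group on the same carbonyl carbon would separate the two.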